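The source may hold more compounds than are shown below. What is called first, only, known or untested is meant among the compounds shown, and "the series" means these compounds.

Working notes on the series. In an assay for inhibition of Deoxyuridine 5'-triphosphate nucleotidohydrolase, mitochondrial (Homo sapiens), read by spectrophotometry (on this read-out higher numbers stand for weaker inhibition and lower numbers for stronger inhibition), compound 2 `O=C(NCCCn1ccc(=O)[nH]c1=O)C(c1ccccc1)c1ccccc1` gives 286000 nM, the lowest of the two numbers in hand. Compound 3 `O=C(c1ccccc1)n1c(=O)ccn(CCCNC(=O)C(c2ccccc2)(c2ccccc2)c2ccccc2)c1=O` gives 1000000 nM, a gap beyond the usual scatter. Compound 1 `O=c1ccn([C@H]2C[C@H](O)[C@@H](CNC(c3ccccc3)c3ccccc3)O2)c(=O)[nH]1` sits at the limit of > 100000 nM in this assay, at which 1 of the 3 values shown sits; its value > 100000 nM is a limit of the assay, not a number.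

Compound 4 `O=C(NCCCO)C(c1ccccc1)c1ccccc1` is not yet measured. It differs from compound 2 by one oxygen atom in place of a group of 8 heavy atoms (4 carbon, 2 nitrogen, 2 oxygen; one six-membered aromatic ring with 2 hetero atoms), on a saturated chain carbon, three bonds along the chain from an amide-type nitrogen. Among the measured compounds shown here, no measured step of this kind is in hand, so the expectation rests on the run of weak values alone; a step toward weaker inhibition, beyond the scatter, is expected, as a 3.5-fold higher number from compound 2 to compound 4 (0.54 log units; beyond the scatter). Compound 4 is estimated to give 1000000 nM, in the range 300000 nM to 3000000 nM, with a fair chance that only a limit is reported.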

Compound 4, inhibition constant: 1000000 nM
The estimate for compound 4 equals the measured number at the digits printed; measured number inside the range.
By their numbers in this assay, from the lowest: compound 2; then compounds 3 and 4 (each within the scatter of the next).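

In this assay, hydroxy in place of the group carrying the six-membered aromatic ring, on a saturated chain carbon three bonds along the chain from an amide-type nitrogen, gives a 3.5-fold higher number from compound 2 to compound 4 (0.54 log units; beyond the scatter). Among the compounds shown here, this is the only readable step, and it shows that this position responds to the change, though modestly; without the ring group, compound 4 still gives 1000000 nM. The data in hand give no cause for this step.

From the compounds shown here alone, whether an amine, a carboxylic acid or a longer chain at this position would match compound 2 or go beyond it remains open.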